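Replacing the Hydroxy Lactone Ring with a Dimethyl Lactone Ring

A few compounds are considered here, and "the series" means these few. Any claim that something is new, unique, unknown or untested is made for them only; others in the source may bear on it.

Three measured compounds share one core and differ only in the ring attached to a chain carbon bound to a sulfur. In an assay on microsomes from liver for inhibition of sterol O-acyltransferase 1 (Rattus norvegicus) (on this read-out lower numbers stand for stronger inhibition and higher numbers for weaker inhibition), compound 1 `C[C@]1(O)CC(=O)OC(CSc2nc(-c3ccccc3)c(-c3ccccc3)[nH]2)C1` gives 140 nM. Compound 2 `O=C1CCCC(CSc2nc(-c3ccccc3)c(-c3ccccc3)[nH]2)O1` gives 740 nM, and compound 3 `O=C1CC(O)CC(CSc2nc(-c3ccccc3)c(-c3ccccc3)[nH]2)O1` gives 910 nM, the highest of the three numbers; its gap to compound 2 lies within the scatter, while its gap to compound 1 lies beyond it.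

Compound 4 `CC1(C)CC(=O)OC(CSc2nc(-c3ccccc3)c(-c3ccccc3)[nH]2)C1` is not yet measured. It differs from compound 3 in that (a group of 9 heavy atoms (7 carbon, 2 oxygen; one six-membered non-aromatic ring with 1 hetero atom) in place of a group of 8 heavy atoms (5 carbon, 3 oxygen; one six-membered non-aromatic ring with 1 hetero atom), on a saturated chain carbon bound to a sulfur). Two kinds of measured step bear on this. The step of a 1.2-fold higher number from compound 2 to compound 3 (0.09 log units; within the scatter) lies within the scatter. By contrast a 5.3-fold higher number from compound 1 to compound 2 (0.72 log units; beyond the scatter) and a 6.5-fold higher number from compound 1 to compound 3 (0.81 log units; beyond the scatter) show that the ring of compound 1 gives a clearly lower number than the rings of compound 2 or compound 3. Going by the values given here, since compound 4 keeps a ring of similar size but with two extra carbons and no hydroxy, a step toward a lower number is expected, a 3.6-fold lower number from compound 3 to compound 4 (0.56 log units; beyond the scatter), though no measured compound carries exactly this ring, so the expectation is uncertain. Compound 4 is therefore estimated at 250 nM, within a range of 70 nM to 900 nM.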

Compound 4, half-maximal inhibitory concentration: 100 nM
For compound 4 the middle estimate is 2.5-fold (0.40 log units) above the measured one, and the stated range covers the measured number.
By their numbers in this assay, from the lowest: compounds 4 and 1 (each within the scatter of the next); then compounds 2 and 3 (each within the scatter of the next).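

In this assay, the result shows that a hydroxy on the ring is not needed for a low number at this position: the ring of compound 4 has none, yet the step to it from the ring of compound 1 stays within the scatter (a 1.4-fold lower number from compound 1 to compound 4 (0.15 log units; within the scatter)). Among these four compounds, the low numbers go with rings carrying extra carbon, as compound 4 differs clearly from both compound 2 (a 7.4-fold lower number from compound 2 to compound 4 (0.87 log units; beyond the scatter)) and compound 3 (a 9.1-fold lower number from compound 3 to compound 4 (0.96 log units; beyond the scatter)), and no compound shown goes against this. No measurement shown here explains the pattern. The compounds shown leave open whether a single methyl on the ring would be enough. They also leave open how a larger group, such as an ethyl or an amine, would behave in that ring.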